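From methoxycarbonyl to benzyloxycarbonyl on the shared core

The source may hold more compounds than are shown below. What is called first, only, known or untested is meant among the compounds shown, and "the series" means these compounds.

In a functional assay on BIU87 cells (Homo sapiens) for cytotoxicity, read by MTT assay (on this read-out lower numbers stand for stronger inhibition and higher numbers for weaker inhibition), three compounds have been read so far. Compound 1 `C=C1C[C@]23C[C@@]1(O)CC[C@H]2[C@@]12C=C[C@H](O)[C@](C)(C(=O)O1)[C@H]2[C@@H]3C(=O)OCc1ccccc1` gives > 100 ug/mL as a limit of the assay and not a number. Compound 2 `C=C1[C@H](O)[C@]23C[C@@]1(OC(C)=O)CC[C@H]2[C@@]12C=C[C@H](OC(C)=O)[C@](C)(C(=O)O1)[C@H]2[C@@H]3C(=O)OCc1ccccc1` gives > 100 ug/mL as a limit too. Among the measured compounds shown here, compound 3 `C=C1C(=O)[C@]23C[C@@]1(Cl)CC[C@H]2[C@@]12C=CC(=O)[C@](C)(C(=O)O1)[C@H]2[C@@H]3C(=O)OC` gives 1 ug/mL as the only true number so far, so its standing rests on a single reading.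

Compound 4 `C=C1C(=O)[C@]23C[C@@]1(Cl)CC[C@H]2[C@@]12C=CC(=O)[C@](C)(C(=O)O1)[C@H]2[C@@H]3C(=O)OCc1ccccc1` departs from compound 3 by phenyl in place of hydrogen on a saturated chain carbon bound to an oxygen next to a carbonyl group in one place: phenyl in place of hydrogen on a saturated chain carbon bound to an oxygen next to a carbonyl group, which reads as methoxycarbonyl to benzyloxycarbonyl. For the measured compounds named here, no measured pair isolates this change. The expected step of a 2.5-fold higher number from compound 3 to compound 4 (0.40 log units; beyond the scatter) is small and toward weaker inhibition. That expectation has compound 3 at 1 ug/mL as its only numerical anchor. For compound 4 the estimated value is 2.5 ug/mL with an expected range of 0.6 ug/mL to 15 ug/mL on this read-out.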

Compound 4, half-maximal inhibitory concentration: 0.5 ug/mL
Estimate against measurement, compound 4: 5.0-fold (0.70 log units) above, and the stated range ends above it.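

In this assay, among the compounds shown here, the first pair that isolates this position gives a 2.0-fold lower number from compound 3 to compound 4 (0.30 log units; within the scatter). Phenyl in place of hydrogen on a saturated chain carbon bound to an oxygen next to a carbonyl group thus leaves the reading with no change beyond the scatter, and compound 4, at 0.5 ug/mL, gives the series a second true number. Nothing shown gives a cause for this step, and the limit reached by other compounds does not bear on it.

As far as these compounds go, whether a carboxylic acid, an amide or a longer chain such as phenethyl would read the same in this place stays open. This is also a single pair on the shared core, so whether methoxycarbonyl to benzyloxycarbonyl behaves alike with other groups elsewhere on the core cannot be told.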